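The source may hold more compounds than are shown below. What is called first, only, known or untested is meant among the compounds shown, and "the series" means these compounds.

In an assay on CHO cells for displacement of a labelled ligand from prostaglandin D2 receptor 2 (Homo sapiens), read by scintillation counting (on this read-out lower numbers stand for stronger inhibition and higher numbers for weaker inhibition), three compounds have been measured. Compound 1 `O=C(O)COc1ccc(Cl)cc1C#Cc1ccc(CO)cc1F` gives 28 nM, and compound 2 `O=C(O)COc1ccccc1C#Cc1ccccc1Cl` gives 747 nM. Compound 3 `CCS(=O)(=O)c1ccc(C)c(C#Cc2cc(Cl)ccc2OCC(=O)O)c1` gives 8.6 nM, the lowest number of the three, and its gaps to both compound 1 and compound 2 lie beyond the usual scatter. Compound 4 `Cc1ccc(S(=O)(=O)N2CCCCC2C)cc1C#Cc1cc(Cl)ccc1OCC(=O)O` is not yet measured. It differs from compound 3 in one place: 2-methylpiperidin-1-yl in place of ethyl on a sulfonyl sulfur. Within the data shown here, no measured pair shows this change, so no step can be read off. The expectation is that compound 4 stays close to compound 3, with a step of a 1.7-fold higher number from compound 3 to compound 4 (0.24 log units; within the scatter) in this assay. Compound 4 is estimated at 15 nM, within a range from 4 nM to 60 nM.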

Compound 4, inhibition constant: 1.9 nM
Compound 4: middle estimate off by 7.9-fold (0.90 log units), on the high side; the measured number lies below the stated range.
By their numbers in this assay, from the lowest: compound 4; then compound 3; then compound 1; then compound 2.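

On a sulfonyl sulfur, ethyl can give way to 2-methylpiperidin-1-yl, a group with a six-membered ring, and the number in this assay still improves (a 4.5-fold lower number from compound 3 to compound 4 (0.66 log units; beyond the scatter)). The earlier compounds shown here gave no hint of this, and this single pair now shows that a far bigger group at this place is compatible with a low number. Nothing measured here gives a reason for the gain.

Open, on these data alone, is whether the gain needs the methyl on the ring, which plain piperidin-1-yl would test. Whether the ring itself matters could be tested with an open-chain diethylamino group on the same sulfur.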